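Alkynyl-uracil phthalimide series: aryl for alkyl at the alkyne

The source may report more compounds than this note shows. Statements on the series, on what has been measured and on what is new or still open speak of the compounds shown alone.

Three members of the series carry a measurement in a functional assay on SW-620 cells (Homo sapiens) for antiproliferative activity, read by MTT assay, with a stated time of 3 days; a lower number here means a stronger inhibitor, a higher number a weaker inhibitor. Compound 1 `Cc1ccc(C#Cc2cn(C/C=C\CN3C(=O)c4ccccc4C3=O)c(=O)[nH]c2=O)cc1` reaches only the limit of the assay and gives > 100000 nM. Compound 2 `CCCCCCCCC#Cc1cn(C/C=C/CN2C(=O)c3ccccc3C2=O)c(=O)[nH]c1=O` gives 87000 nM and has the higher of the two numbers; compound 3 `CCCCC#Cc1cn(C/C=C\CN2C(=O)c3ccccc3C2=O)c(=O)[nH]c1=O` gives 82000 nM, and the two values lie within the scatter of each other, so no order between compound 2 and compound 3 is claimed. Among the measured compounds shown here, the single step between compounds differing in one place runs from compound 1 to compound 3 and shows an at least 1.2-fold lower number from compound 1 to compound 3 (0.08 log units; that floor lies within the scatter), a floor set by the limit described in the limit of > 100000 nM in this assay, at which 1 of the 3 values shown sits.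

Compound 4 `CCCCc1ccc(C#Cc2cn(C/C=C/CN3C(=O)c4ccccc4C3=O)c(=O)[nH]c2=O)cc1` differs from compound 2 by 4-butylphenyl in place of octyl on a triple-bonded carbon. This is the counterpart, in the opposite direction, of the step from compound 1 to compound 3, where an aryl group gave way to a chain and the number fell by an amount not resolvable from the scatter. For compound 4 a number of the same size as compound 2 or somewhat higher is therefore expected, with a fair chance that only the limit is reported. The step from compound 2 to compound 4 is estimated at a 1.1-fold higher number from compound 2 to compound 4 (0.06 log units; within the scatter). Compound 4 is expected at 100000 nM, within 45000 nM to 250000 nM.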

Compound 4, half-maximal inhibitory concentration: > 100000 nM
Compound 4 was reported as a limit (the forecaster's own chance of this, stated with the estimate: 45%); the middle value sits exactly at the limit.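

Notes on the aryl-for-chain change on the triple-bonded carbon: in this assay, 4-butylphenyl in place of octyl gives an at least 1.1-fold higher number from compound 2 to compound 4 (0.06 log units; that floor lies within the scatter), so the change can now be followed on the second double-bond geometry in the series, and not only on the pair of compound 1 and compound 3. Across both pairs the chain-bearing member, compound 2 or compound 3, returns a measured number and the aryl-bearing member, compound 4 or compound 1, returns only a limit, with no listed compound going against this, yet neither step is resolved beyond the scatter. The true size of the step stays unread because compound 4, like compound 1, gives a limit and not a number: the limit of > 100000 nM in this assay, at which 2 of the 4 values shown sit.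

On these data alone, whether an aryl group on this carbon truly gives a weaker result than a chain therefore remains open, as does what the double-bond geometry contributes on its own. Also open, as far as these compounds go, is whether an amine or a carboxylic acid in place of octyl on a triple-bonded carbon would bring the number well clear of the limit.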